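This account rests on a few compounds, and the source may have more. Where it says the series, first, only, none or still open, it means among the compounds named here.

Compound 3 `COC(=O)C1C(=O)C(C(=O)OC)[C@H](c2ccccn2)N(CCCC(=O)O)[C@@H]1c1ccccn1` sits at the upper end of the two numbers measured in an ADME assay on J774.1 cells (Mus musculus) for cytotoxicity, with a stated time of 48 h (a higher number here means that more compound is needed for the effect, a lower number that less compound is needed), where compound 3 gives 46 uM. Compound 1 `Clc1cccc(Cl)c1CO/N=C/C1CCN(CCCc2ccccc2)CC1` gives 28.4 uM in this assay, a value within the usual scatter of that of compound 3, so the two cannot be told apart. Compound 2 `COC(=O)c1c(-c2ccccn2)n(Cc2ccc(Cl)cc2)c(-c2ccccn2)cc1=O` reaches only a limit of this assay, at > 100 uM. Compound 4 `COC(=O)C1C(=O)C(C(=O)OC)[C@H](c2ccccn2)N(CCCCCCCC(=O)O)[C@@H]1c1ccccn1` has not been measured yet. It differs from compound 3 in one place: 4-carboxybutyl in place of carboxy on a saturated chain carbon, three bonds along the chain from an amine nitrogen in a ring. For the measured compounds named here, no measured pair shows a change of this kind. The step of a 1.2-fold lower number from compound 3 to compound 4 (0.06 log units; within the scatter) is expected to stay within the scatter. Compound 4 is therefore estimated at 40 uM, with a range from 15 uM to 100 uM.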

Compound 4, concentration for half-maximal effect: 33.8 uM
Compound 4: middle estimate off by 1.2-fold (0.07 log units), on the high side; low and high end bracket the measured number.
By their numbers in this assay, from the lowest: compounds 1, 4 and 3 (each within the scatter of the next). At a limit, above all of these: compound 2.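

Putting 4-carboxybutyl in place of carboxy on a saturated chain carbon, three bonds along the chain from an amine nitrogen in a ring, gives a 1.4-fold lower number from compound 3 to compound 4 (0.13 log units; within the scatter) in this assay. This first measured pair shows that, on this core, the longer chain carrying the carboxylic acid leaves the cytotoxicity reading unchanged within the scatter. Nothing available bears on why the reading holds. Still open, as far as these compounds go, is whether a methyl ester or an amine in place of the carboxylic acid would move the number, and whether a still longer chain would.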